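A few compounds are considered here, and "the series" means these few. Any claim that something is new, unique, unknown or untested is made for them only; others in the source may bear on it.

In a functional assay on A549 cells (Homo sapiens) for inhibition (on this read-out higher numbers stand for weaker inhibition and lower numbers for stronger inhibition), compound 3 `COc1cc(/C=C\c2cn(C(C)=O)c3ccccc23)cc(OC)c1OC` gives 2850 nM, and this lies within the scatter of compound 1 `COCCOc1cc(/C=C\c2ccc3ccccc3c2)ccc1OC` at 2990 nM. Compound 2 `COc1cc(/C=C/c2cn(C(C)=O)c3ccccc23)cc(OC)c1OC` reports only a limit, > 5000 nM. Thus only two exact numbers are available, and they do not separate from each other.

The next structure is compound 4 `COc1cc(/C=C\c2c[nH]c3ccccc23)cc(OC)c1OC`, with hydrogen in place of acetyl on an aromatic nitrogen. The double bond and the rest of compound 3 stay unchanged.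

For the measured compounds named here, the one measured step is an at least 1.7-fold lower number from compound 2 to compound 3 (0.24 log units; that floor lies within the scatter). It concerns (the fact that compounds 2 and 3 differ only in the configuration as drawn), so it says nothing directly about the group on the nitrogen, and its size is also clipped by the limit of > 5000 nM in this assay, at which 1 of the 3 values shown sits. Going by the values given here, no measured pair in this set changes the acetyl, so the data give no direct size for this step. Only a weakly informed expectation is possible: a modest shift towards a lower number, barely beyond the scatter, with no change also plausible.

The expected change is a 1.9-fold lower number from compound 3 to compound 4 (0.28 log units; within the scatter). Compound 4 is estimated at 1500 nM, with an expected range from 300 nM to 5000 nM.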

Compound 4, half-maximal inhibitory concentration: 3230 nM
Compound 4: the middle estimate sits 2.2-fold (0.33 log units) below what was measured; low and high end bracket the measured number.
By their numbers in this assay, from the lowest: compounds 3, 1 and 4 (each within the scatter of the next). At a limit, above all of these: compound 2.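

Hydrogen in place of acetyl on the aromatic nitrogen gives, in this assay, a 1.1-fold higher number from compound 3 to compound 4 (0.05 log units; within the scatter), which is the first measured size for any change at this position. With the Z double bond and the rest of the shared core held constant, the acetyl, with its 3 heavy atoms and 1 hydrogen-bond acceptor, can leave this nitrogen without a change in the number that stands out from the scatter, so this pair gives no sign that the read-out depends on that group. No information at hand gives a reason for this outcome, and a flat step between two compounds does not by itself establish one.

As far as these compounds go, whether another group on the same nitrogen, such as methyl, a longer chain or a sulfonyl group, would move the number beyond the scatter remains open, since hydrogen and acetyl are the only two substituents compared here. From the compounds shown here alone, the same change on the E double bond of compound 2, whose > 5000 nM is a limit of the assay, also remains open.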